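Swapping Methyl for Methoxy on a Glutamate Receptor Modulator

The compounds below may be only part of what the source reports. "The series", "measured", "known", "first", "only" and "open" are said of these compounds alone.

Compound 1 `COc1cc(C(=O)O)ccc1OCCCCOc1ccc(C(=O)C(C)C)c(O)c1C`: 73.1%
Compound 2 `Cc1cc(C(=O)O)ccc1OCCCCOc1ccc(C(=O)CC(C)C)c(O)c1C`: 83.9%
Compound 3 `CCCC(=O)c1ccc(OCCCCOc2ccc(F)c(C(=O)O)c2)c(C)c1O`: 87.5%

All three were tested in an assay on HEK293 cells for positive allosteric modulation of metabotropic glutamate receptor 2 (Rattus norvegicus), read by thallium flux, with a stated time of 2.5 min; a higher number here means a larger maximal response, a lower number a smaller maximal response. Compound 2 stands second highest of the three. Its number and that of compound 3 lie within the usual scatter of each other, whereas compound 1 sits beyond the scatter below compound 2. Compound 4 `COc1cc(C(=O)O)ccc1OCCCCOc1ccc(C(=O)CC(C)C)c(O)c1C` has not yet been measured. Going by the values given here, it differs from compound 2 in one place: methoxy in place of methyl on an aromatic carbon No measured pair isolates this change, so its effect is not known. Compound 1 also carries a methoxy group and gives the lowest number, but it differs from compound 2 elsewhere too, so only a small downward step, possibly none beyond the scatter, is expected in this assay. Compound 4 is expected to give 77%, between 63% and 91%. The estimated step of a number 6.9 percentage points lower from compound 2 to compound 4 (within the scatter) is modest.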

Compound 4, largest response reached (reported as percent of maximum), in percent of the reference or control that the assay uses: 85.7%
Estimate against measurement, compound 4: 8.7 percentage points below, within the range that was stated.
By their numbers in this assay, from the lowest: compound 1; then compounds 2, 4 and 3 (each within the scatter of the next).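

Methoxy in place of methyl on this aromatic carbon, ortho to a large group, comes to a number 1.8 percentage points higher from compound 2 to compound 4 (within the scatter) in this assay, so this swap leaves the maximal response unmoved. Isobutyl in place of isopropyl on a carbonyl carbon gives a number 12.6 percentage points higher from compound 1 to compound 4 (beyond the scatter) and thus ties the low number of compound 1 to that chain, not to its methoxy. Nothing measured here explains either step.

On these data alone, whether an ethoxy group, a chlorine atom or an amine at this position would be tolerated equally stays open. So does whether a longer chain on the carbonyl carbon would raise the response further.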